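This account rests on a few compounds, and the source may have more. Where it says the series, first, only, none or still open, it means among the compounds named here.

Working notes on a small chalcone-type series. Compound 1 `COc1cc(O)c(C(=O)/C=C/c2ccc(O)c(O)c2)c(OC)c1` carries two hydroxy groups on the ring attached to the double-bonded chain; in a functional assay on B16-F10 cells (Mus musculus) for inhibition, with a stated time of 4 days (a lower number here means a stronger inhibitor, a higher number a weaker inhibitor), compound 1 gives 31600 nM. Compound 2 `COc1cc(O)c(C(=O)/C=C/c2cccc(O)c2)c(OC)c1` keeps one of them, and in this assay compound 2 gives 9900 nM. Going by the values given here, the single measured step, a 3.2-fold lower number from compound 1 to compound 2 (0.50 log units; beyond the scatter), is hydrogen in place of hydroxy on an aromatic carbon. On the two numbers shown, compound 2 stands lowest, its nearest neighbour being compound 1.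

Compound 3 `COc1cc(O)c(C(=O)/C=C/c2ccccc2O)c(OC)c1` is not yet measured. It differs from compound 2 by 2-hydroxyphenyl in place of 3-hydroxyphenyl on a double-bonded chain carbon bound to a double-bonded chain carbon; the two have the same atoms, joined differently. Among the compounds with values here, no measured step in this set moves a hydroxy group within the ring, so the step from compound 1 to compound 2 bears only loosely on it, and no step beyond the scatter is expected in this assay. Compound 3 is expected at 12000 nM, range 4000 nM to 36000 nM, meaning an expected step of a 1.2-fold higher number from compound 2 to compound 3 (0.08 log units; within the scatter).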

Compound 3, half-maximal inhibitory concentration: 2300 nM
Beside the measured number, compound 3's estimate is 5.2-fold (0.72 log units) above it; the measured number lies below the stated range.
By their numbers in this assay, from the lowest: compound 3; then compound 2; then compound 1.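

Moving the one hydroxy group on the chain-bound ring gives a 4.3-fold lower number from compound 2 to compound 3 (0.63 log units; beyond the scatter) in this assay, with 2-hydroxyphenyl in place of 3-hydroxyphenyl and the counted atoms, donors and acceptors unchanged. The earlier step, a 3.2-fold lower number from compound 1 to compound 2 (0.50 log units; beyond the scatter), changed how many hydroxy groups the ring carried, whereas this one shows that, on a double-bonded chain carbon bound to a double-bonded chain carbon, the choice between two isomeric groups is enough to give a step beyond the scatter. Nothing at hand bears on what lies behind this difference.

On these data alone, whether the lower number of compound 3 would persist with an amine or a carboxylic acid in place of its hydroxy group remains open. As far as these compounds go, the contribution of the hydroxy and methoxy groups on the other ring also remains open, as all three compounds share them unchanged.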